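This account rests on a few compounds, and the source may have more. Where it says the series, first, only, none or still open, it means among the compounds named here.

Measured compounds:
- compound 1, `Cc1nc(S(C)(=O)=O)ccc1Oc1ncnc(OC2CCN(C(=O)O[C@@H](C)CF)CC2)c1F`, gives 1680 nM in a functional assay on isolated protein for inhibition of Glucose-dependent insulinotropic receptor (Rattus norvegicus), read by HTRF and cAMP accumulation; on this read-out lower numbers stand for an effect already at smaller amounts and higher numbers for an effect only at larger amounts of compound
- compound 2, `Cc1nc(S(C)(=O)=O)ccc1Oc1ncnc(OC2CCN(C(=S)OC(C)C)CC2)c1F`, gives 1050 nM
- compound 3, `Cc1nc(S(C)(=O)=O)ccc1Oc1ncnc(OC2CCN(C(=O)C(C)(F)F)CC2)c1F`, gives 239 nM

All three share one core and differ only in the group carried on the ring nitrogen of the piperidine. Compound 3 stands at the lowest number of the three; its nearest neighbour is compound 2, and the gap between them is a 4.4-fold lower number from compound 2 to compound 3 (0.64 log units; beyond the scatter), while the gap from compound 1 is a 7.0-fold lower number from compound 1 to compound 3 (0.85 log units; beyond the scatter). Both of these steps run beyond the usual scatter, so compound 3 is the most potent of the measured set.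

Compound 4, `Cc1nc(S(C)(=O)=O)ccc1Oc1ncnc(OC2CCN(C(=O)c3noc(C(C)C)n3)CC2)c1F`, is not yet measured. It differs from compound 3 by the exchange (5-isopropyl-1,2,4-oxadiazol-3-yl in place of 1,1-difluoroethyl on a carbonyl carbon). For the measured compounds named here, the step that bears most directly on it is the one from compound 1 to compound 3, also an exchange on the same carbonyl carbon, which gave a 7.0-fold lower number from compound 1 to compound 3 (0.85 log units; beyond the scatter). The step from compound 2 to compound 3, a 4.4-fold lower number from compound 2 to compound 3 (0.64 log units; beyond the scatter), shows the same direction but concerns the whole group on the ring nitrogen. Neither step involves an aromatic ring entering at this position, so the record gives no direct guide to the size of the coming step. The step that is expected here is a 1.9-fold higher number from compound 3 to compound 4 (0.27 log units; within the scatter), and the uncertainty around it is wide. For compound 4 in this assay, the estimated value is 450 nM, expected to fall between 110 nM and 1800 nM.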

Compound 4, half-maximal effective concentration: 176 nM
Compound 4: middle estimate off by 2.6-fold (0.41 log units), on the high side; measured number inside the range.
By their numbers in this assay, from the lowest: compounds 4 and 3 (each within the scatter of the next); then compounds 2 and 1 (each within the scatter of the next).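

In this assay, the carbonyl carbon accepts 5-isopropyl-1,2,4-oxadiazol-3-yl, a larger group with a five-membered aromatic ring and hydrogen-bond acceptors, about as well as it accepts 1,1-difluoroethyl, which has neither (a step of a 1.4-fold lower number from compound 3 to compound 4 (0.13 log units; within the scatter)). For the compounds shown here, this is the first sign that an aromatic ring can sit at this position, and the low number holds against the two weaker carbamate-type groups on the ring nitrogen, with steps beyond the scatter in both cases (a 6.0-fold lower number from compound 2 to compound 4 (0.78 log units; beyond the scatter); a 9.5-fold lower number from compound 1 to compound 4 (0.98 log units; beyond the scatter)). No measurement shown here explains why these numbers fall as they do.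

The compounds shown cannot separate the contribution of the oxadiazole ring from that of its isopropyl group, and a methyl or cyclopropyl group on the same ring would test that directly. As far as these compounds go, it also remains open whether the ring itself must be an oxadiazole, or whether a phenyl or pyridine ring on the same carbonyl carbon would give a similar number in this assay.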